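The source may report more compounds than this note shows. Statements on the series, on what has been measured and on what is new or still open speak of the compounds shown alone.

Measured so far:
- compound 1, `CC(C)n1nc(-c2ccnc3[nH]c(C4CCN(CC(=O)N(C)C)CC4)cc23)ccc1=O`: 2 uL/min
- compound 2, `CC(C)n1cc(-c2ccnc3[nH]c(C4CCN(CC(=O)N5CCCCC5)CC4)cc23)ccc1=O`: 8 uL/min

Two compounds have been run in an ADME assay on cells (Hepatocyte, Homo sapiens) for metabolic stability; on this read-out higher numbers stand for fast clearance and lower numbers for slow clearance. Compound 1 gives 2 uL/min and compound 2 gives 8 uL/min, so compound 2 stands highest of the two numbers, with compound 1 as its nearest neighbour at a lower value, a gap that lies beyond the usual scatter. For the measured compounds named here, no single-point step connects these two, and their numbers are taken simply as they stand.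

Compound 3, `CC(C)n1cc(-c2ccnc3[nH]c(C4CCN(CC(=O)N(C)C)CC4)cc23)ccc1=O`, has not yet been measured. It differs from compound 2 in one place: dimethylamino in place of piperidin-1-yl on a carbonyl carbon. Compound 1, which gives 2 uL/min in this assay, also carries a dimethylamino group at this carbonyl carbon, though its core differs from the core shared by compound 2 and compound 3. On that basis the step of a 2.3-fold lower number from compound 2 to compound 3 (0.36 log units; beyond the scatter) is expected to run downward, of modest size, possibly no larger than the scatter. Compound 3 is estimated at 3.5 uL/min, within 1.5 uL/min to 8 uL/min.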

Compound 3, intrinsic clearance in a liver preparation (reported as CLH), per the amount of preparation that the assay uses in the Hepatocyte assay: < 1 uL/min
Compound 3 was reported as a limit (the forecaster's own chance of this, stated with the estimate: 5%); at least 3.5-fold (0.54 log units) between middle value and limit.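

In the Hepatocyte assay the result for compound 3 is a limit of the assay and not a number: the limit of < 1 uL/min in the Hepatocyte assay, at which 1 of the 3 values shown sits.

Even so, in the Hepatocyte assay this one change on the carbonyl carbon, with the core held the same, gives an at least 8.0-fold lower number from compound 2 to compound 3 (0.90 log units; beyond the scatter), the first direct sign that the group at this position matters; the change of core gives an at least 2.0-fold lower number from compound 1 to compound 3 (0.30 log units; that floor lies within the scatter), and with that floor within the scatter the pair does not show whether the core matters. In a physicochemical assay for acid dissociation, compound 2 gives 7.8 and compound 3 gives 7.9, two values within the scatter of each other.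

The compounds shown leave open how the read-out follows the size of this group, since a single pair cannot separate the ring from the number of carbons. Pyrrolidin-1-yl, morpholin-4-yl or diethylamino on the same carbonyl carbon would fill that gap.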